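Trimming the ether side chain of an indazolyl phthalazinone

The compounds below may be only part of what the source reports. "The series", "measured", "known", "first", "only" and "open" are said of these compounds alone.

Compound 1: `O=C(O)Cn1nc(Cn2cc3cc(OCC4CC4)c(Cl)cc3n2)c2ccccc2c1=O` — in a functional assay on CHO cells for antagonist activity at sphingosine 1-phosphate receptor 2 (Homo sapiens), read by GTPgammaS binding (a lower number here means a stronger inhibitor, a higher number a weaker inhibitor), compound 1 gives 53 nM.
Compound 2: `C[C@H](C(=O)O)n1nc(Cn2cc3cc(OCC4CC4)c(Cl)cc3n2)c2ccccc2c1=O` — in this assay compound 2 gives 15 nM.

Of the two compounds with numbers, compound 1 has the higher one; its nearest neighbour is compound 2, and the move from the hydrogen to the methyl on the chain carbon carrying the acid gives a 3.5-fold lower number from compound 1 to compound 2 (0.55 log units; beyond the scatter). Compound 3 is `CCOc1cc2cn(Cc3nn(CC(=O)O)c(=O)c4ccccc34)nc2cc1Cl`. It keeps the acetic acid side chain of compound 1 and differs from it at the other end of the shared core: methyl in place of cyclopropyl on a saturated chain carbon bound to an oxygen on an aromatic ring. Neither measured step touches this position; both compound 1 and compound 2 carry the cyclopropylmethoxy group, so the shown pair only tells how the acid-bearing carbon responds, not how the ether does. Without a step at the ether, compound 3 is expected to sit close to compound 1, with a wide margin on either side, so that the expected step is a 1.5-fold higher number from compound 1 to compound 3 (0.18 log units; within the scatter). Compound 3 is therefore estimated at 80 nM in this assay, with a range from 25 nM to 260 nM.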

Compound 3, half-maximal inhibitory concentration: 113 nM
Estimate against measurement, compound 3: 1.4-fold (0.15 log units) below, and the stated range covers the measured number.
By their numbers in this assay, from the lowest: compound 2; then compound 1; then compound 3.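

The ether position, which neither compound of the earlier pair varied, now has a step of its own: in this assay, methyl in place of cyclopropyl on the saturated chain carbon bound to an oxygen on an aromatic ring, which turns cyclopropylmethoxy into ethoxy, gives a 2.1-fold higher number from compound 1 to compound 3 (0.33 log units; beyond the scatter). The position therefore responds to this change, though the step is modest and only just clears the usual scatter, so the cyclopropyl ring can be removed here with only a small rise in the number. Nothing available bears on why the number moves at this position.

With only cyclopropylmethoxy and ethoxy shown at this position, it remains open how a methoxy group, a longer chain such as propoxy, or a larger ring such as cyclobutylmethoxy would read in this assay, and so whether the number follows the size of the group or depends on the ring itself. As far as these compounds go, it also remains open whether the ethoxy group would give a step of similar size on the side chain of compound 2, which carries the methyl on the carbon bearing the carboxylic acid.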